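Replacing the (4-methylphenyl)amino group of compound 3

The source may report more compounds than this note shows. Statements on the series, on what has been measured and on what is new or still open speak of the compounds shown alone.

Among the measured compounds shown here, in a functional assay on MDA-MB-231 cells (Homo sapiens) for antiproliferative activity, read by MTT assay, with a stated time of 24 h (a lower number here means a stronger inhibitor, a higher number a weaker inhibitor), compound 3 (`Cc1ccc(NC(=O)N2CCN(c3nccc(Oc4cc(Cl)cc(Cl)c4)n3)CC2)cc1`) gives 11600 nM, the lower of the two actual numbers so far. Compound 2 (`COc1ccc(S(=O)(=O)N2CCN(c3nccc(Oc4cc(Cl)cc(Cl)c4)n3)CC2)cc1`) gives a higher 46800 nM, a gap beyond the scatter. Compound 1 (`CC(C)(C)c1ccc(S(=O)(=O)N2CCN(c3nccc(Oc4cc(Cl)cc(Cl)c4)n3)CC2)cc1`) reads > 50000 nM, which is a limit of the assay and not a number.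

Compound 4 (`CN1CCN(CC(=O)N2CCN(c3nccc(Oc4cc(Cl)cc(Cl)c4)n3)CC2)CC1`) keeps the shared core and differs from compound 3 as follows: (4-methylpiperazin-1-yl)methyl in place of (4-methylphenyl)amino on a carbonyl carbon. Thus (4-methylpiperazin-1-yl)methyl stands in place of (4-methylphenyl)amino on a carbonyl carbon. For the measured compounds named here, the only measured step, an at least 1.0-fold lower number from compound 1 to compound 2 (0.02 log units; that floor lies within the scatter), puts methoxy in place of tert-butyl on an aromatic carbon and does not touch the carbonyl carbon, so it gives no size for this change. Compound 2, which also lacks the (4-methylphenyl)amino group, gives 46800 nM, so a move toward a higher number is expected. The estimated move is a 2.2-fold higher number from compound 3 to compound 4 (0.33 log units; beyond the scatter). For compound 4 the expected value is 25000 nM, with an estimated range from 8000 nM to 50000 nM.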

Compound 4, half-maximal inhibitory concentration: 24700 nM
Compound 4: middle estimate off by 1.0-fold (0.01 log units), on the high side; the range from low to high includes it.
By their numbers in this assay, from the lowest: compound 3; then compounds 4 and 2 (each within the scatter of the next). At a limit, above all of these: compound 1.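

In this assay, among the compounds shown here, the exchange of (4-methylphenyl)amino for (4-methylpiperazin-1-yl)methyl gives a 2.1-fold higher number from compound 3 to compound 4 (0.33 log units; beyond the scatter) on the carbonyl carbon, the first measured change at this place. The entering group holds the same number of heavy atoms as the leaving one, but the aromatic ring and the hydrogen-bond donor both go, and this goes with a step that is modest yet beyond the scatter, with compound 4 still reading as a number and not a limit. No measurement shown accounts for this step.

The compounds shown leave open whether the move follows the loss of the aromatic ring or the loss of the hydrogen-bond donor, as both go in the same step. A benzyl group on the same carbonyl carbon, which keeps an aromatic ring of carbon only and carries no such donor, would separate the two.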